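Replacing the indolyl arm with a tert-butyl group

A few compounds are considered here, and "the series" means these few. Any claim that something is new, unique, unknown or untested is made for them only; others in the source may bear on it.

Measured compounds:
compound 1 `Fc1ccc(CN2CCC(NCCSC(c3ccc(F)cc3)c3ccc(F)cc3)CC2)cc1` 25.5 nM
compound 2 `O=C(c1ccc(F)cc1)N1CCC(NCCSC(c2ccc(F)cc2)c2ccc(F)cc2)CC1` 7.04 nM
compound 3 `Fc1ccc(C(SCCNC2CCN(Cc3cc4ccccc4[nH]3)CC2)c2ccc(F)cc2)cc1` 179 nM

All three were tested in an assay on membranes from striatum (strain Sprague-Dawley) for displacement of a labelled ligand from sodium-dependent dopamine transporter (Rattus norvegicus), read by scintillation counting, with a stated time of 120 min; on this read-out lower numbers stand for stronger inhibition and higher numbers for weaker inhibition. Compound 3 gives the highest number of the three: compound 1 sits below it by a 7.0-fold higher number from compound 1 to compound 3 (0.85 log units; beyond the scatter) read in reverse, and compound 2 further still, the gap being a 25-fold higher number from compound 2 to compound 3 (1.41 log units; beyond the scatter) read in reverse.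

Compound 4 `CC(C)(C)CN1CCC(NCCSC(c2ccc(F)cc2)c2ccc(F)cc2)CC1` has not yet been measured in this assay. It differs from compound 3 in one place: tert-butyl in place of 1H-indol-2-yl on a saturated chain carbon bound to an amine nitrogen in a ring. Among the compounds with values here, no measured step exchanges an aromatic substituent for a saturated one on this carbon, so the comparison is indirect. The nearest guide is the step from compound 1 to compound 3, a 7.0-fold higher number from compound 1 to compound 3 (0.85 log units; beyond the scatter), which shows that this position shifts the read-out by a modest amount when the group is changed; the step of a 3.6-fold lower number from compound 1 to compound 2 (0.56 log units; beyond the scatter) shows that variation at the ring nitrogen also moves the number modestly. Since compound 3 already stands highest, the estimate for compound 4 is a modest step downward, a 3.0-fold lower number from compound 3 to compound 4 (0.47 log units; beyond the scatter), giving an expected value of 60 nM with a range from 15 nM to 250 nM.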

Compound 4, inhibition constant: 279 nM
Compound 4: the middle estimate sits 4.7-fold (0.67 log units) below what was measured; measured number outside the range, above it.
By their numbers in this assay, from the lowest: compound 2; then compound 1; then compounds 3 and 4 (each within the scatter of the next).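

Read in this assay, tert-butyl and 1H-indol-2-yl on this saturated chain carbon cannot be told apart (a 1.6-fold higher number from compound 3 to compound 4 (0.19 log units; within the scatter)), even though tert-butyl has no ring and no hydrogen-bond donor. Of the three groups placed on this carbon, only 4-fluorophenyl stands apart, since tert-butyl also lies clearly on the weaker side of it (an 11-fold higher number from compound 1 to compound 4 (1.04 log units; beyond the scatter)), and on the amine nitrogen in a ring, neopentyl gives way far more to (4-fluorophenyl)carbonyl (a 40-fold higher number from compound 2 to compound 4 (1.60 log units; beyond the scatter)). No evidence at hand bears on why these numbers fall as they do.

From the compounds shown here alone, whether a plain phenyl or a cyclohexyl on this carbon would sit with compound 1 or with compounds 3 and 4 stays open. Also open, going by these compounds, is what an amine or a carboxylic acid at the same place would do to the number.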